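A few compounds are considered here, and "the series" means these few. Any claim that something is new, unique, unknown or untested is made for them only; others in the source may bear on it.

Three analogues on one shared core have been run in a functional assay on MDA-MB-468 cells (Homo sapiens) for cytotoxicity, with a stated time of 48 h; on this read-out lower numbers stand for stronger inhibition and higher numbers for weaker inhibition. Compound 1 `O=[N+]([O-])c1ccc(CN2CCC(n3cc(CC(OCc4cc(-c5ccc(F)cc5)no4)c4ccc(Br)cc4)nn3)CC2)cc1` gives 4000 nM. Compound 2 `COc1ccc(-c2cc(COC(Cc3cn(C4CCN(Cc5ccc([N+](=O)[O-])cc5)CC4)nn3)c3ccc(Br)cc3)on2)cc1` carries methoxy in place of fluoro on an aromatic carbon and gives 9000 nM, a step of a 2.3-fold higher number from compound 1 to compound 2 (0.35 log units; beyond the scatter). Compound 3 `O=[N+]([O-])c1ccc(CN2CCC(n3cc(CC(OCc4cc(-c5ccccc5F)no4)c4ccc(Br)cc4)nn3)CC2)cc1` differs from compound 1 by 2-fluorophenyl in place of 4-fluorophenyl on an aromatic carbon; the two cores are told apart only in this way. In this assay compound 3 gives 4000 nM, and compound 3 and compound 1 read the same.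

Compound 4 `COc1ccccc1-c1cc(COC(Cc2cn(C3CCN(Cc4ccc([N+](=O)[O-])cc4)CC3)nn2)c2ccc(Br)cc2)on1` bears methoxy in place of fluoro on an aromatic carbon. This is the same kind of change as that made in compound 2, not the same: in compound 2 the methoxy sits para to a large group, in compound 4 ortho to a large group. Because the step of a 2.3-fold higher number from compound 1 to compound 2 (0.35 log units; beyond the scatter) was modest and beyond the scatter, a step of about that size is expected here: a 2.0-fold higher number from compound 3 to compound 4 (0.30 log units; within the scatter). Compound 4 is therefore estimated to give about 8000 nM in this assay, between 3500 nM and 18000 nM.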

Compound 4, half-maximal inhibitory concentration: > 25000 nM
Compound 4: a limit, no number; the forecaster's own chance of this, stated with the estimate: 5%; middle value at least 3.1-fold (0.49 log units) away from the limit.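

Compound 4 stands at > 25000 nM in this assay, which is a limit of the assay and not a number. With 2-methoxyphenyl in place of 4-methoxyphenyl the read-out shows an at least 2.7-fold higher number from compound 2 to compound 4 (0.44 log units; beyond the scatter), with 2-methoxyphenyl in place of 4-fluorophenyl it shows an at least 6.2-fold higher number from compound 1 to compound 4 (0.79 log units; beyond the scatter), and methoxy in place of fluoro shows an at least 6.2-fold higher number from compound 3 to compound 4 (0.79 log units; beyond the scatter), so this change does not carry over at one size between the two cores: the same change on two cores in this assay, a 2.3-fold higher number (0.35 log units; beyond the scatter) from compound 1 to compound 2 and an at least 6.2-fold higher number (0.79 log units; beyond the scatter) from compound 3 to compound 4, at least 2.7-fold (0.44 log units) apart, beyond the scatter of two such steps. Both pairs move the same way, but they fix only a minimum for the second step, not its true size, and two pairs set no rule for the series.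

Still open, going by these compounds, is how a 2-hydroxyphenyl or 2-aminophenyl group would read on this core. Also open, on these data alone, is whether the gap between the two methoxy steps persists with a chloro group in place of the bromo group.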